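A few compounds are considered here, and "the series" means these few. Any claim that something is new, unique, unknown or untested is made for them only; others in the source may bear on it.

The measured compounds in this set:

Compound 1, `CCCCc1c(F)c(N)c2c(=O)cc(-c3ccc(N)c(F)c3)oc2c1F`. In a functional assay on HeLa cells (Homo sapiens) for cytotoxicity, read by neutral red uptake, with a stated time of 3 days (a lower number here means a stronger inhibitor, a higher number a weaker inhibitor), compound 1 gives > 100000 nM, which is a limit of the assay and not a number.
Compound 2, `COc1c(F)c(N)c2c(=O)cc(-c3ccc(N)c(F)c3)oc2c1F`. In this assay compound 2 gives 34000 nM.
Compound 3, `CCOC(=O)c1c(F)c(N)c2c(=O)cc(-c3ccc(N)c(F)c3)oc2c1F`. In this assay compound 3 gives > 100000 nM, again a limit rather than a number.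

Compound 3 thus stands at the limit of > 100000 nM in this assay, at which 2 of the 3 values shown sit, and only compound 2 has a readable number. The step of an at least 2.9-fold higher number from compound 2 to compound 3 (0.46 log units; beyond the scatter) is at least modest and upward, whereas the step that the two limits leave unreadable from compound 1 to compound 3 cannot be sized, since both of its ends are limits. Among the compounds with values here, the only step with two readable ends is an at least 2.9-fold lower number from compound 1 to compound 2 (0.46 log units; beyond the scatter).

Compound 4, `CN(C)CC(=O)OCc1c(F)c(N)c2c(=O)cc(-c3ccc(N)c(F)c3)oc2c1F`, differs from compound 3 by ((((dimethylamino)methyl)carbonyl)oxy)methyl in place of ethoxycarbonyl on an aromatic carbon. Within the data shown here, no measured step exchanges one ester-bearing group for another at this aromatic carbon, so the bearing of the three steps is indirect: they show that changes at this position have so far moved the number by a modest amount at most, and that two of the three compounds sit at the limit. Compound 4 is therefore expected to stay weak, with a real chance of another limit, and its estimate is 80000 nM within 20000 nM to 200000 nM. Among the measured compounds shown here, the expected step is an at least 1.2-fold lower number from compound 3 to compound 4 (0.09 log units; that floor lies within the scatter), that is, no step that can be read beyond the scatter.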

Compound 4, half-maximal inhibitory concentration: 9200 nM
The estimate for compound 4 lay 8.7-fold (0.94 log units) above the measured number, and the stated range ends above it.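

The ((((dimethylamino)methyl)carbonyl)oxy)methyl group shows that this aromatic carbon, ortho to two fluoro groups, can carry a change with a large effect on the number, since putting it in place of ethoxycarbonyl gives an at least 10-fold lower number from compound 3 to compound 4 (1.03 log units; beyond the scatter). The same group also gives a 3.7-fold lower number from compound 2 to compound 4 (0.57 log units; beyond the scatter) and an at least 10-fold lower number from compound 1 to compound 4 (1.03 log units; beyond the scatter), so compound 4 holds the lowest number of the four in this assay, and the position is no longer one where the compounds shown reach only modest steps. The two large steps are floors rather than sizes, as compound 1 and compound 3 each stand at a limit and not at a number: the limit of > 100000 nM in this assay, at which 2 of the 4 values shown sit.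

The change brings in a nitrogen and a larger group at once, and the compounds shown do not tell which part of it goes with the lower number. From the compounds shown here alone, a hydroxymethyl group, a plain dimethylaminomethyl group or a carboxylic acid on this carbon would each separate the amine from the ester, and the step's meaning remains open until such a comparison is available.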